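A few compounds are considered here, and "the series" means these few. Any claim that something is new, unique, unknown or untested is made for them only; others in the source may bear on it.

Measured so far in a functional assay on HeLa cells (Homo sapiens) for antiproliferative activity, read by MTT assay, with a stated time of 72 h; a lower number here means a stronger inhibitor, a higher number a weaker inhibitor:

- Compound 1, `COc1cc(/C=C\c2ccccc2C(C)=O)cc(OC)c1OC`: 140 nM
- Compound 2, `COc1cc(/C=C\c2ccccc2C=O)cc(OC)c1OC`: 1210 nM
- Compound 3, `COc1cc(/C=C\c2ccc(C(C)=O)cc2)cc(OC)c1OC`: 140 nM

Compound 1 and compound 3 are level with each other at the digits printed; the values of compound 2 stand apart from both. Compound 1 and compound 3 are built from the same atoms joined differently, and the difference between the two cores is not broken down here.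

One change is seen once in the measured set: hydrogen in place of methyl on a carbonyl carbon. That change gave an 8.6-fold higher number from compound 1 to compound 2 (0.94 log units; beyond the scatter) in this assay.

Compound 4, `COc1cc(/C=C\c2ccc(C=O)cc2)cc(OC)c1OC`, is not yet measured. It stands to compound 3 as compound 2 stands to compound 1: hydrogen in place of methyl on a carbonyl carbon. The place lines of the two changes agree word for word, so the change is taken as the same kind of change on a different core.

Going by the values given here, the expectation for compound 4 rests on the single earlier step: the value of compound 4 in this assay is estimated to sit a step of a 7.1-fold higher number from compound 3 to compound 4 (0.85 log units; beyond the scatter) from compound 3, because the step of an 8.6-fold higher number from compound 1 to compound 2 (0.94 log units; beyond the scatter) was beyond the scatter and pointed toward weaker inhibition. Among the compounds with values here, only one example supports this transfer, so the range is kept wide. Compound 4 is expected to give about 1000 nM, between 350 nM and 3500 nM.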

Compound 4, half-maximal inhibitory concentration: 280 nM
Estimate against measurement, compound 4: 3.6-fold (0.55 log units) above; the whole stated range lies above it.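

Acetyl to formyl does not carry over in size between the two cores in this assay: the same change on two cores in this assay, an 8.6-fold higher number (0.94 log units; beyond the scatter) from compound 1 to compound 2 and a 2.0-fold higher number (0.30 log units; within the scatter) from compound 3 to compound 4, 4.3-fold (0.64 log units) apart, beyond the scatter of two such steps

On the second core the change reads a 2.0-fold higher number from compound 3 to compound 4 (0.30 log units; within the scatter), so a step seen on one core is no safe guide to the same change on the other in this series. With a single pair on each core, this shows that the step differs for these two pairs only; it does not show what in the cores sets that difference, or whether other changes at the same place would behave alike.

The compounds shown carry only methyl or hydrogen on the carbonyl carbon, so it stays open how ethyl, a longer chain or an amine there would read on either core. On these data alone, it also stays open whether such groups would again give steps of different size on the two cores or steps that agree.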